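The source may report more compounds than this note shows. Statements on the series, on what has been measured and on what is new or still open speak of the compounds shown alone.

Measured so far:
- compound 1, `Nc1nc(N)nc(-c2cc(C(F)(F)F)ccc2Cl)n1`: 2.27
- compound 2, `Nc1nc(N)nc(-c2cccc(C(F)(F)F)c2)n1`: 2.67

In a physicochemical assay for lipophilicity (on this read-out higher numbers stand for higher lipophilicity and lower numbers for lower lipophilicity), compound 1 gives 2.27, the lowest of the two numbers; its nearest neighbour is compound 2 at 2.67. Within the data shown here, the one measured step, a number 0.40 log units higher from compound 1 to compound 2 (beyond the scatter), concerns a chloro group and is the only comparison available in this assay.

Compound 3, `Nc1nc(N)nc(-c2ccccc2Cl)n1`, is not yet measured. It differs from compound 1 as follows: hydrogen in place of trifluoromethyl on an aromatic carbon. Among the measured compounds shown here, no measured step covers a trifluoromethyl group, so the chloro step from compound 1 to compound 2 bears on it only as a guide to the general size of single-group changes, not to the direction of this one.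

The expectation is nonetheless that compound 3 sits lower than compound 1, by a number 0.87 log units lower from compound 1 to compound 3 (beyond the scatter), a step estimated to lie beyond the scatter. In this assay compound 3 is estimated at 1.4, with a range from 1 to 1.8.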

Compound 3, partition coefficient: 1.19
Estimate against measurement, compound 3: 0.21 log units above, and the stated range covers the measured number.
By their numbers in this assay, from the lowest: compound 3; then compound 1; then compound 2.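

In this assay, among these compounds, the change from trifluoromethyl to hydrogen on this aromatic carbon, para to a chloro group, gives a number 1.08 log units lower from compound 1 to compound 3 (beyond the scatter) and is the first step that reads on this position. It is graded large, while a number 0.40 log units higher from compound 1 to compound 2 (beyond the scatter) at the chloro group is graded modest, so the two single-group changes from compound 1 run in opposite directions. No measurement shown accounts for the size of the trifluoromethyl step.

The compounds shown leave open whether this step keeps its size when the chloro group is absent. They also leave open where a methyl, a methoxy or a nitrile on the same aromatic carbon would fall relative to hydrogen and trifluoromethyl.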